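Ester change at a carbonyl carbon and Vero cell cytotoxicity

This account rests on a few compounds, and the source may have more. Where it says the series, first, only, none or still open, it means among the compounds named here.

Three esters sharing one core were examined in an ADME assay on Vero cells (Chlorocebus sabaeus) for cytotoxicity, read by MTT assay, with a stated time of 48 h; on this read-out lower numbers stand for stronger inhibition and higher numbers for weaker inhibition. Compound 1 `C=CC(=O)OC1CCC(CN2CCN(c3cc(=O)c4cc(C(F)(F)F)cc([N+](=O)[O-])c4s3)CC2)CC1` carries a vinyl on the carbonyl carbon; in this assay compound 1 reaches only the limit > 64 ug/mL. Compound 2 `CC(=O)OC1CCC(CN2CCN(c3cc(=O)c4cc(C(F)(F)F)cc([N+](=O)[O-])c4s3)CC2)CC1` has a methyl in place of vinyl on the carbonyl carbon, and in this assay compound 2 likewise gives the limit > 64 ug/mL. Compound 3 `CC(C)C(=O)OC1CCC(CN2CCN(c3cc(=O)c4cc(C(F)(F)F)cc([N+](=O)[O-])c4s3)CC2)CC1` has an isopropyl in place of methyl on the carbonyl carbon, and in this assay compound 3 again stops at the limit > 64 ug/mL. Compound 3 therefore stands at the same limit as the other two, so that the steps a step that the two limits leave unreadable from compound 1 to compound 2, a step that the two limits leave unreadable from compound 1 to compound 3 and a step that the two limits leave unreadable from compound 2 to compound 3 cannot be sized, because of the limit of > 64 ug/mL in this assay, at which 3 of the 3 values shown sit.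

Compound 4 `O=C(OC1CCC(CN2CCN(c3cc(=O)c4cc(C(F)(F)F)cc([N+](=O)[O-])c4s3)CC2)CC1)c1cccc(F)c1` is the next ester: 3-fluorophenyl in place of isopropyl on a carbonyl carbon. For the measured compounds named here, no measured step bears on this change in a readable way, since every step among the three measured compounds lies between two limits. Nothing among them points to a step beyond the scatter in either direction in this assay. Compound 4 is therefore expected to give a step that the limit leaves unreadable from compound 3 to compound 4, and its estimated value in this assay is 80 ug/mL, within the range 40 ug/mL to 200 ug/mL, most probably reported again only as a limit.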

Compound 4, half-maximal inhibitory concentration: > 64 ug/mL
Compound 4 was reported as a limit; the forecaster's own chance of this, stated with the estimate: 80%; the middle value does not contradict the limit.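

In this assay compound 4 gives > 64 ug/mL, which is a limit and not a number. No step from compound 1, compound 2 or compound 3 to compound 4 can be read, because each value is only a limit: the limit of > 64 ug/mL in this assay, at which 4 of the 4 values shown sit.

The compounds shown leave open how the vinyl, methyl, isopropyl and 3-fluorophenyl esters compare in this assay.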